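Furan-3-yl for 3-chlorophenyl: a step from compound 3

This account rests on a few compounds, and the source may have more. Where it says the series, first, only, none or still open, it means among the compounds named here.

Compound 1 `COc1cccc(Cc2cc(-c3ccccc3)nn(CC(=O)Nc3ccc(F)cc3)c2=O)c1` gives > 50000 nM in a functional assay on HL-60 cells (Homo sapiens), read by calcium flux (on this read-out higher numbers stand for an effect only at larger amounts of compound and lower numbers for an effect already at smaller amounts), a limit.
Compound 2 `COc1ccc(Cc2cc(-c3ccc(F)cc3)nn(CC(=O)Nc3ccc(Br)cc3)c2=O)cc1` gives > 50000 nM in this assay, again a limit.
Compound 3 `Cc1cc(Cc2cccc(Cl)c2)c(=O)n(CC(=O)Nc2ccc(Br)cc2)n1` gives > 50000 nM in this assay, also a limit.

None of the three values is a number; each is the limit of this assay (the limit of > 50000 nM in this assay, at which 3 of the 3 values shown sit). Compound 3 therefore stands level with compound 1 and compound 2 on what is shown, and no order among them can be read. Among the measured compounds shown here, no step between measured compounds that differ in one place exists in this set, so no measured step size is available to lean on.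

Compound 4 `Cc1cc(Cc2ccoc2)c(=O)n(CC(=O)Nc2ccc(Br)cc2)n1` is not yet measured. It differs from compound 3 by furan-3-yl in place of 3-chlorophenyl on a saturated chain carbon bound to an aromatic carbon; cut one bond further out, 3-chlorobenzyl becomes (furan-3-yl)methyl. With every measured value at the limit, the expectation for this step is no change beyond the scatter: the outcome is expected to be another limit rather than a number. The expected step is a step that the limit leaves unreadable from compound 3 to compound 4. Compound 4 is estimated at 60000 nM, with a range from 20000 nM to 200000 nM, most likely reported again as a limit.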

Compound 4, half-maximal effective concentration: > 50000 nM
Compound 4 was reported as a limit (the forecaster's own chance of this, stated with the estimate: 85%); the middle value is on the limit's open side.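

Compound 3 and compound 4 both stand as limits in this assay, so no step can be read for furan-3-yl in place of 3-chlorophenyl: the limit of > 50000 nM in this assay, at which 4 of the 4 values shown sit.

The compounds shown leave open whether any member of this series gives a measurable value in this assay, and whether any of the groups varied here bears on the read-out at all.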